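Ester in place of amide on the shared core

The source may hold more compounds than are shown below. What is called first, only, known or untested is meant among the compounds shown, and "the series" means these compounds.

Compound 1 `CC[C@@H](C)[C@H](NC(=O)c1ccc(C(CC)(CC)c2ccc(OCC(=O)C(C)(C)C)c(C)c2)n1CC)C(=O)OC` gives 590 nM in an assay on HL-60 cells for agonist activity at vitamin D3 receptor (Homo sapiens), read by microscopy, with a stated time of 96 h; on this read-out lower numbers stand for an effect already at smaller amounts and higher numbers for an effect only at larger amounts of compound.
Compound 2 `C#CCNC(=O)c1ccc(C(CC)(CC)c2ccc(OCC(=O)C(C)(C)C)c(C)c2)n1CC` gives 2200 nM in this assay.
Compound 3 `C=CCN(C)C(=O)c1ccc(C(CC)(CC)c2ccc(OCC(=O)C(C)(C)C)c(C)c2)n1CC` gives 21600 nM in this assay.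

Compound 3 stands highest of the three in this assay; compound 2 is nearest and compound 1 furthest, both with lower numbers. Compound 4 `C#CC(C)OC(=O)c1ccc(C(CC)(CC)c2ccc(OCC(=O)C(C)(C)C)c(C)c2)n1CC` differs from compound 3 in one place: (1-methylprop-2-yn-1-yl)oxy in place of allyl(methyl)amino on a carbonyl carbon. Going by the values given here, no measured step exchanges an amide for an ester, so the direct bearing is slim. The nearest guide is a 9.8-fold higher number from compound 2 to compound 3 (0.99 log units; beyond the scatter), where a propargyl group on nitrogen gave the lower number; compound 4 carries a triple bond again, though on oxygen. A step back toward compound 2 is therefore expected, because of a 9.8-fold higher number from compound 2 to compound 3 (0.99 log units; beyond the scatter), but with wide uncertainty. For compound 4 the expected value is 6000 nM, in the range 1200 nM to 30000 nM, which means an expected 3.6-fold lower number from compound 3 to compound 4 (0.56 log units; beyond the scatter).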

Compound 4, half-maximal effective concentration: 210 nM
The estimate for compound 4 lay 29-fold (1.46 log units) above the measured number; measured number below the stated range.
By their numbers in this assay, from the lowest: compound 4; then compound 1; then compound 2; then compound 3.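

In this assay, an ester on this carbonyl carbon gives a much lower number than the allyl(methyl)amino amide (a 100-fold lower number from compound 3 to compound 4 (2.01 log units; beyond the scatter)). A triple bond alone does not set the number, since compound 2 also carries one, yet the change to (1-methylprop-2-yn-1-yl)oxy still lowers it (a 10-fold lower number from compound 2 to compound 4 (1.02 log units; beyond the scatter)); this small group also beats the larger group of compound 1 (a 2.8-fold lower number from compound 1 to compound 4 (0.45 log units; beyond the scatter)). Nothing available explains these drops. Still open, as far as these compounds go, is how much belongs to the oxygen and how much to the added methyl, and whether a carboxylic acid or a longer chain here would keep the number low.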